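The source may hold more compounds than are shown below. What is called first, only, known or untested is meant among the compounds shown, and "the series" means these compounds.

Measured in a functional assay on K562 cells (Homo sapiens) for cytotoxicity, read by trypan blue exclusion, with a stated time of 96 h; on this read-out lower numbers stand for stronger inhibition and higher numbers for weaker inhibition:
- Compound 1 `COC(=O)CCNc1cc(CS(=O)(=O)/C=C/c2c(OC)cc(OC)cc2OC)ccc1OC`: 1000 nM
- Compound 2 `COC(=O)[C@H](C)Nc1cc(CS(=O)(=O)/C=C/c2c(OC)cc(OC)cc2OC)ccc1OC`: 200 nM
- Compound 3 `COC(=O)C(C)(C)Nc1cc(CS(=O)(=O)/C=C/c2c(OC)cc(OC)cc2OC)ccc1OC`: 800 nM

Compound 3 holds the second highest of these numbers. The nearest value gives a 1.3-fold lower number from compound 1 to compound 3 (0.10 log units; within the scatter), while the furthest gives a 4.0-fold higher number from compound 2 to compound 3 (0.60 log units; beyond the scatter). Compound 4 `COC(=O)C(Nc1cc(CS(=O)(=O)/C=C/c2c(OC)cc(OC)cc2OC)ccc1OC)c1ccc(F)cc1`, not yet measured, carries (4-fluorophenyl)(methoxycarbonyl)methyl in place of 1-(methoxycarbonyl)-1-methylethyl on a nitrogen on an aromatic ring. For the measured compounds named here, the steps that bear on this change are those at the same nitrogen, a 5.0-fold lower number from compound 1 to compound 2 (0.70 log units; beyond the scatter) and a 4.0-fold higher number from compound 2 to compound 3 (0.60 log units; beyond the scatter), both modest. Compound 4 resembles compound 2 in having a single group alongside the methoxycarbonyl on that carbon, but no aromatic group has been tested there. In this assay the expected change is modest and downward, an estimated 1.6-fold lower number from compound 3 to compound 4 (0.20 log units; within the scatter). For compound 4 the estimated value is 500 nM, with an expected range from 120 nM to 1600 nM.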

Compound 4, half-maximal inhibitory concentration: 800 nM
Estimate against measurement, compound 4: 1.6-fold (0.20 log units) below; measured number inside the range.
By their numbers in this assay, from the lowest: compound 2; then compounds 3, 4 and 1 (each within the scatter of the next).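

In this assay, the first aromatic ring at this nitrogen substituent, in (4-fluorophenyl)(methoxycarbonyl)methyl, gives no change at the digits printed from compound 3 to compound 4 (within the scatter) and a 1.3-fold lower number from compound 1 to compound 4 (0.10 log units; within the scatter). For the compounds shown here, it does not keep the lower number of the 1-(methoxycarbonyl)ethyl group, with a 4.0-fold higher number from compound 2 to compound 4 (0.60 log units; beyond the scatter), so having only one group other than methoxycarbonyl on that carbon is not enough to reproduce the result of compound 2. Nothing measured here accounts for this difference.

As far as these compounds go, whether phenyl without the fluorine, or a carboxylic acid in place of the methyl ester, would give a different number remains open.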